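Notes on hydrogen in place of chloro in compound 3

This account rests on a few compounds, and the source may have more. Where it says the series, first, only, none or still open, it means among the compounds named here.

Measured so far in an ADME assay on GES1 cells (Homo sapiens) for cytotoxicity, read by MTT assay, with a stated time of 24 h; a higher number here means that more compound is tolerated, a lower number that less compound is tolerated:
- compound 1 `CC1(C)[C@H]2CC[C@]1(C)N(Cc1cn(-c3ccc(C#N)cc3)nn1)C(=O)C2` gives 11300 nM
- compound 2 `CC1(C)[C@H]2CC[C@]1(C)N(Cc1cn(-c3ccccc3Cl)nn1)C(=O)C2` gives 5370 nM
- compound 3 `CC1(C)[C@H]2CC[C@]1(C)N(Cc1cn(-c3cccc(Cl)c3)nn1)C(=O)C2` gives 69800 nM
- compound 4 `CC1(C)[C@H]2CC[C@]1(C)N(Cc1cn(-c3ccccc3)nn1)C(=O)C2` is not yet measured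

Compound 3 stands highest of the three measured numbers, with the other two lower beyond the scatter. The change to compound 4 hydrogen in place of chloro on an aromatic carbon puts hydrogen in place of chloro on an aromatic carbon, meta to a large group. For the measured compounds named here, no measured step makes this exact change. The closest evidence concerns substitution on the same phenyl group: a 13-fold higher number from compound 2 to compound 3 (1.11 log units; beyond the scatter) is large, while a 6.2-fold higher number from compound 1 to compound 3 (0.79 log units; beyond the scatter) and a 2.1-fold lower number from compound 1 to compound 2 (0.32 log units; beyond the scatter) are modest. A modest step down in this assay is therefore expected, with the direction less than certain. The expected step is a 2.5-fold lower number from compound 3 to compound 4 (0.40 log units; beyond the scatter) on this estimate. For compound 4 the estimated value is 28000 nM within an expected range of 8000 nM to 90000 nM for now.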

Compound 4, half-maximal cytotoxic concentration: 6690 nM
Beside the measured number, compound 4's estimate is 4.2-fold (0.62 log units) above it; measured number outside the range, below it.
By their numbers in this assay, from the lowest: compounds 2, 4 and 1 (each within the scatter of the next, the first and the last beyond it); then compound 3.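

In this assay the high number of compound 3 depends on its chloro group: a 10-fold lower number from compound 3 to compound 4 (1.02 log units; beyond the scatter) removes almost all of its lead. The plain phenyl group gives no separation from the other two substituents, with a 1.2-fold higher number from compound 2 to compound 4 (0.10 log units; within the scatter) and a 1.7-fold lower number from compound 1 to compound 4 (0.23 log units; within the scatter) both within the scatter, so among these compounds only the 3-chlorophenyl group stands apart. Nothing measured here accounts for this difference. 

Going by these compounds, it remains open whether bromo, methyl or an amine on the same aromatic carbon would give a similarly high number. On these data alone, it also remains open whether the chloro step holds on a core other than the shared one.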